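The source may hold more compounds than are shown below. What is called first, only, known or untested is meant among the compounds shown, and "the series" means these compounds.

Measured so far:
compound 1, `Nc1cc(Cc2ccn(Cc3cccc(Oc4cccc5c4CNC5)c3)n2)c2nn[nH]c2n1` — 1700 nM
compound 2, `Nc1cc(Cc2ccn(-c3ccccc3)n2)c2nn[nH]c2n1` — 640 nM

In an assay on cells for inhibition of thyroid peroxidase (Homo sapiens), with stated times of 10 min and 15 min (a higher number here means a weaker inhibitor, a lower number a stronger inhibitor), compound 1 gives 1700 nM, the highest of the two numbers in hand. The nearest point is compound 2, whose number in this assay is lower by a margin that lies beyond the usual scatter; the two structures differ in more than one place, so no single step can be read from that pair.

Compound 3, `Nc1cc(Cc2ccn(Cc3cccc(Oc4ccccc4)c3)n2)c2nn[nH]c2n1`, is the next compound to be measured in this assay. It differs from compound 1 in one place: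
a group of 6 heavy atoms (6 carbon; one six-membered aromatic ring of carbon only) in place of a group of 9 heavy atoms (8 carbon, 1 nitrogen; one five-membered non-aromatic ring with 1 hetero atom, one six-membered aromatic ring of carbon only), on an oxygen on an aromatic ring

Within the data shown here, no step between two measured compounds isolates this change, so the expectation rests on the shared core and on the fact that compound 2, the simpler of the two measured compounds, carries the lower number. For compound 3 the step of a 1.5-fold higher number from compound 1 to compound 3 (0.17 log units; within the scatter) is expected to be small, pointing towards a somewhat higher number, and it may well stay within the scatter. Compound 3 is therefore estimated at 2500 nM in this assay, with a range from 900 nM to 7000 nM.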

Compound 3, half-maximal inhibitory concentration: 1100 nM
Beside the measured number, compound 3's estimate is 2.3-fold (0.36 log units) above it, within the range that was stated.
By their numbers in this assay, from the lowest: compounds 2, 3 and 1 (each within the scatter of the next, the first and the last beyond it).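

In this assay, among these compounds, this is the first step that isolates one place: on the oxygen on an aromatic ring, phenyl in place of the group of 9 heavy atoms gives a 1.5-fold lower number from compound 1 to compound 3 (0.19 log units; within the scatter). The five-membered non-aromatic ring with 1 hetero atom, and with it the 1 hydrogen-bond donor and 1 hydrogen-bond acceptor counted for the leaving group, can therefore go from this place without a change that can be told from the scatter, so on this pair the number does not depend on that ring. No measurement in hand on either group bears on this result, which stays an observation without an explanation.

Going by these compounds, it remains open whether a group of another kind on the same oxygen, such as an amine or a carboxylic acid on the phenyl ring, or a pyridine ring in place of phenyl, would give a step beyond the scatter. Compound 2 differs from compound 1 and from compound 3 in more than one place, so what sets its number apart cannot be read from these compounds.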